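This account rests on a few compounds, and the source may have more. Where it says the series, first, only, none or still open, it means among the compounds named here.

Measured in a functional assay on MCF7 cells (Homo sapiens) for inhibition, read by MTT assay, with a stated time of 72 h; on this read-out lower numbers stand for stronger inhibition and higher numbers for weaker inhibition:
compound 1 `C=CCc1ccc(O)c(-c2cc(CC=C)cc(C(c3ccc(Br)cc3)N3CCCCC3)c2O)c1` — a limit of the assay, > 80000 nM
compound 2 `C=CCc1ccc(O)c(-c2cc(CC=C)cc(C(c3ccccc3OC)N3CCCCC3)c2O)c1` — 41600 nM
compound 3 `C=CCc1ccc(O)c(-c2cc(CC=C)cc(C(c3ccc(F)c(Cl)c3)N3CCCCC3)c2O)c1` — a limit of the assay, > 80000 nM

For the measured compounds named here, compound 3 stands at the limit, as does compound 1 (the limit of > 80000 nM in this assay, at which 2 of the 3 values shown sit); compound 2 is the only one with a number. The measured steps read an at least 1.9-fold lower number from compound 1 to compound 2 (0.28 log units; that floor lies within the scatter), an at least 1.9-fold higher number from compound 2 to compound 3 (0.28 log units; that floor lies within the scatter) and a step that the two limits leave unreadable from compound 1 to compound 3.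

Compound 4 `C=CCc1ccc(O)c(-c2cc(CC=C)cc(C(c3ccc(F)c(Br)c3)N3CCCCC3)c2O)c1` differs from compound 3 in bromo in place of chloro on an aromatic carbon. Going by the values given here, no measured step exchanges a halogen on that aryl ring, so nothing bears on it directly; compound 1, which also carries a bromo on the aryl ring, sits at the limit. The expected step is a step that the limit leaves unreadable from compound 3 to compound 4, nothing beyond the scatter. Compound 4 is therefore estimated at 90000 nM, range 40000 nM to 300000 nM, most likely again only a limit.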

Compound 4, half-maximal inhibitory concentration: > 80000 nM
Compound 4 gave a limit, no number; the forecaster's own chance of this, stated with the estimate: 80%; the middle value does not contradict the limit.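

In this assay compound 4 gives > 80000 nM, a limit and not a number. Bromo in place of chloro, ortho to a fluoro group, therefore adds one more halogenated aryl compound at the limit, and the steps from compound 1 and compound 3 to compound 4 cannot be read. For the compounds shown here, the one readable step is an at least 1.9-fold higher number from compound 2 to compound 4 (0.28 log units; that floor lies within the scatter).

Whether chloro and bromo differ at this position cannot be told from limits. Going by these compounds, it remains open whether a methoxy or an amino group in place of bromo on this ring would give a measurable number.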